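A few compounds are considered here, and "the series" means these few. Any claim that something is new, unique, unknown or untested is made for them only; others in the source may bear on it.

In an assay on HEK293 cells for displacement of a labelled ligand from Sigma non-opioid intracellular receptor 1 (Homo sapiens), read by scintillation counting, with a stated time of 120 min (a lower number here means a stronger inhibitor, a higher number a weaker inhibitor), three compounds have been measured:

Compound 1 `CNC1CCN(c2ncnc3c2cnn3CCN2CCCCC2)C1`: 25800 nM
Compound 2 `c1cn(-c2ncnc3c2cnn3CCN2CCCCC2)cn1`: 13800 nM
Compound 3 `Cc1cccc(-c2ncnc3c2cnn3CCN2CCCCC2)c1`: 82 nM

Compound 3 gives the lowest number of the three, and both steps leading to it are large: a 310-fold lower number from compound 1 to compound 3 (2.50 log units; beyond the scatter) and a 170-fold lower number from compound 2 to compound 3 (2.23 log units; beyond the scatter). Compound 4 `Fc1cc(Cl)ccc1-c1ncnc2c1cnn2CCN1CCCCC1` is the next compound to test. It differs from compound 3 in one place: 4-chloro-2-fluorophenyl in place of 3-methylphenyl on an aromatic carbon. The two large measured steps each replaced a nitrogen-containing group with a six-membered aromatic ring of carbon only; here that carbon ring is kept and only its substituents change, so neither step maps onto this change. The number for compound 4 is therefore expected to stay close to that of compound 3, with a step of a 1.2-fold higher number from compound 3 to compound 4 (0.09 log units; within the scatter), and the estimate is 100 nM with a range from 30 nM to 400 nM.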

Compound 4, inhibition constant: 112 nM
For compound 4 the middle estimate is 1.1-fold (0.05 log units) below the measured one; measured number inside the range.
By their numbers in this assay, from the lowest: compounds 3 and 4 (each within the scatter of the next); then compounds 2 and 1 (each within the scatter of the next).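

In this assay the swap of 3-methylphenyl for 4-chloro-2-fluorophenyl gives a 1.4-fold higher number from compound 3 to compound 4 (0.14 log units; within the scatter) and so shows that this position accepts more than one substituted carbon ring. The new group also brings a 120-fold lower number from compound 2 to compound 4 (2.09 log units; beyond the scatter) and a 230-fold lower number from compound 1 to compound 4 (2.36 log units; beyond the scatter) so the large gain over the nitrogen-containing groups is not tied to 3-methylphenyl alone. No evidence at hand bears on the reason for these steps.

Still open, from the compounds shown here alone, is whether the chlorine and the fluorine each matter on their own. Also open, going by these compounds, is whether plain phenyl, or a carbon ring carrying an amine or a carboxylic acid, would hold this level.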